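The source may report more compounds than this note shows. Statements on the series, on what has been measured and on what is new or still open speak of the compounds shown alone.

Measured compounds:
- compound 1 `N=C(N)N/N=C/c1c(-c2cccs2)nc2sccn12`: 24000 nM
- compound 2 `N=C(N)N/N=C/c1c(-c2ccsc2)nc2sccn12`: 29500 nM
- compound 3 `Cc1cn2c(/C=N/Nc3ccccn3)c(-c3ccc(Cl)c([N+](=O)[O-])c3)nc2s1`: 42700 nM

In a functional assay on cells (Cancer cell lines, Homo sapiens) for inhibition (on this read-out lower numbers stand for stronger inhibition of growth and higher numbers for weaker inhibition of growth), compound 1 gives 24000 nM, the smallest of the three numbers, yet the other two lie close: compound 2 sits a step of a 1.2-fold higher number from compound 1 to compound 2 (0.09 log units; within the scatter) away, and compound 3 at 42700 nM is separated from compound 1 by a gap that also falls within the scatter. The three numbers therefore describe one flat cluster and no ordering among them is supported.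

Compound 4 `Cc1cn2c(/C=N/NC(=N)N)c(-c3cccs3)nc2s1` differs from compound 1 in one place: methyl in place of hydrogen on an aromatic carbon. For the measured compounds named here, no measured pair isolates this change. Going by the values given here, the only single-point step on record, a 1.2-fold higher number from compound 1 to compound 2 (0.09 log units; within the scatter), concerns the thiophenyl attachment and was within the scatter, so it gives no guide to the methyl. Compound 3 does carry the methyl on the same ring as compound 4, but it also differs from compound 1 at the hydrazone and the aryl group, so its value speaks only to the whole set of changes, and that value stays within the scatter of compound 1.

On this basis no step beyond the scatter is expected in this assay: the estimated move is no change at the digits printed from compound 1 to compound 4 (within the scatter). For compound 4 the expected value is 24000 nM, with a range from 10000 nM to 55000 nM.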

Compound 4, concentration for total growth inhibition: 8130 nM
The estimate for compound 4 lay 3.0-fold (0.47 log units) above the measured number; the whole stated range lies above it.
By their numbers in this assay, from the lowest: compound 4; then compounds 1, 2 and 3 (each within the scatter of the next).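

In this assay, for the compounds shown here, the step of a 3.0-fold lower number from compound 1 to compound 4 (0.47 log units; beyond the scatter) is the one single-place change on hand that lies beyond the scatter, whereas the change from thiophen-2-yl to thiophen-3-yl, a 1.2-fold higher number from compound 1 to compound 2 (0.09 log units; within the scatter), does not. This position, on an aromatic carbon next to the ring sulfur, therefore responds to the entry of methyl in place of hydrogen, a change of a single carbon, even though the step is modest and rests on one matched pair. No available measurement accounts for this step, so its origin remains unassigned.

The compounds shown leave open whether the lower number is particular to methyl or would also follow from ethyl, a chlorine atom, a methoxy group or an amine at the same carbon. Going by these compounds alone, they also leave open whether methyl brings a step of similar size with thiophen-3-yl in place of thiophen-2-yl, or with a hydrazone partner other than the one shared by compound 1 and compound 4.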